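The source may report more compounds than this note shows. Statements on the series, on what has been measured and on what is new or still open speak of the compounds shown alone.

Measured so far:
compound 1, `CN1CCN(c2ccc(Nc3ncc4c(n3)N(C3CCCC3)CC(=O)N4)cc2)CC1`: 5220 nM
compound 2, `CN1CCN(c2ccc(Nc3ncc4c(n3)N(C3CCCC3)CC(=O)N4)nc2)CC1`: 26500 nM
compound 3, `CN1CCN(c2ccc(Nc3ncc4c(n3)N(C3CCCC3)CC(=O)N4C)cc2)CC1`: 7560 nM

These three compounds share most of their structure and were all tested in a functional assay on HT-29 cells (Homo sapiens) for inhibition, read by MTT assay, with a stated time of 48 h; on this read-out higher numbers stand for weaker inhibition and lower numbers for stronger inhibition. Compound 1 and compound 3 differ in one place only: methyl in place of hydrogen on an amide-type nitrogen in a ring. That change made a 1.4-fold higher number from compound 1 to compound 3 (0.16 log units; within the scatter), so on this read-out compound 1 and compound 3 cannot be told apart. Compound 2 has a different core from compound 1; how the two cores differ is not broken down here, and the numbers simply show that compound 2 carries the highest value of the three, with compound 3 nearer to it than compound 1.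

Compound 4, `CN1CCN(c2ccc(Nc3ncc4c(n3)N(C3CCCC3)CC(=O)N4C)nc2)CC1`, has not yet been measured. It stands to compound 2 as compound 3 stands to compound 1: the difference is methyl in place of hydrogen on an amide-type nitrogen in a ring. The place where the methyl enters is described in exactly the same words for both pairs, so this is the same change, applied now to the core of compound 2 instead of the core of compound 1.

Going by the values given here, the only guide to the size of this step is the earlier one, and that one stayed within the scatter. The expectation for compound 4 is therefore a 1.3-fold higher number from compound 2 to compound 4 (0.12 log units; within the scatter), resting on the measured pair compound 1 to compound 3 having given a 1.4-fold higher number from compound 1 to compound 3 (0.16 log units; within the scatter). Starting from the value of compound 2, compound 4 is expected to give about 35000 nM in this assay, most likely between 14000 nM and 85000 nM.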

Compound 4, half-maximal inhibitory concentration: 11100 nM
Estimate against measurement, compound 4: 3.2-fold (0.50 log units) above; measured number outside the range, below it.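

In this assay, putting methyl in place of hydrogen on the amide-type nitrogen gave a 2.4-fold lower number from compound 2 to compound 4 (0.38 log units; beyond the scatter) on the core of compound 2, a modest step but one that can be read as real. Set beside the first case, this shows that the same small change did not have the same outcome on the two cores, so its size on one core was a poor guide to its size on the other: the same change on two cores in this assay, a 1.4-fold higher number (0.16 log units; within the scatter) from compound 1 to compound 3 and a 2.4-fold lower number (0.38 log units; beyond the scatter) from compound 2 to compound 4, 3.5-fold (0.54 log units) apart, beyond the scatter of two such steps. Going by these compounds alone, it does not show why the two cores respond differently, and with only two pairs it gives no rule for a further core; nor does it make methyl a good change in general, since one step is too small to read and the other is modest.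

The compounds shown have only hydrogen or methyl on this nitrogen, so it remains open how an ethyl group, a longer chain or a chain ending in an amine or a carboxylic acid would behave on either core. On these data alone, it is also open whether the gap between the two steps would hold with a group other than cyclopentyl on the ring.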